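This account rests on a few compounds, and the source may have more. Where it says the series, first, only, none or still open, it means among the compounds named here.

Three compounds built on a shared core have been run through an ADME assay on microsomes from liver (Homo sapiens) for metabolic stability, tested at 2.5 uM; a higher number here means faster removal of the compound, a lower number slower removal. Compound 1 `O=S(=O)(c1ccc(F)cc1)c1cnc2c(F)cccc2c1-c1cccc(F)c1` gives 1.56 mL/min, compound 2 `O=S(=O)(c1cccc(F)c1)c1cnc2c(F)cccc2c1-c1ccccc1F` gives 0.21 mL/min, and compound 3 `COc1cccc(-c2c(S(=O)(=O)c3cccc(F)c3)cnc3c(F)cccc23)c1` gives 2.6 mL/min. Compound 3 thus holds the highest number of the three; its gap to compound 1 lies within the scatter, while its gap to compound 2 is beyond it. Going by the values given here, the one measured step that bears on the next move is a 12-fold higher number from compound 2 to compound 3 (1.09 log units; beyond the scatter), where 3-methoxyphenyl took the place of 2-fluorophenyl on an aromatic carbon. Compound 4 `O=S(=O)(c1cccc(F)c1)c1cnc2c(F)cccc2c1-c1cccc(F)c1` is compound 3 with one change: fluoro in place of methoxy on an aromatic carbon. Compound 1 already carries the same 3-fluorophenyl group as compound 4 and differs from it only in the aryl group on the sulfonyl, and its number sits close to that of compound 3. Among the compounds with values here, no measured step swaps methoxy for fluoro, so that single large step gives only a loose sense of how far a change on this ring can move the number. A small shift toward a lower number, staying within the scatter, is expected: a 1.7-fold lower number from compound 3 to compound 4 (0.24 log units; within the scatter). Compound 4 is accordingly estimated at 1.5 mL/min, with a range from 0.6 mL/min to 3.5 mL/min.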

Compound 4, intrinsic clearance in a liver preparation (reported as CLH), per the amount of preparation that the assay uses: 1.14 mL/min
Beside the measured number, compound 4's estimate is 1.3-fold (0.12 log units) above it; the range from low to high includes it.
By their numbers in this assay, from the lowest: compound 2; then compounds 4, 1 and 3 (each within the scatter of the next, the first and the last beyond it).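

In this assay, the swap of methoxy for fluoro on this aromatic carbon, meta to a large group, gives a 2.3-fold lower number from compound 3 to compound 4 (0.36 log units; beyond the scatter), which shows that the identity of the group at this place matters on its own, with the position on the ring held the same. The earlier step from compound 2 to compound 3 changed both the group and its place on the ring, whereas with fluoro kept on the ring and only its place changed, 3-fluorophenyl in place of 2-fluorophenyl gives a 5.4-fold higher number from compound 2 to compound 4 (0.73 log units; beyond the scatter), so the low number of compound 2 goes with the 2-fluorophenyl group and not only with the absence of methoxy. On the other aryl group, 3-fluorophenyl in place of 4-fluorophenyl on the sulfonyl sulfur gives a 1.4-fold lower number from compound 1 to compound 4 (0.14 log units; within the scatter), a step that stays within the scatter, so this move of the fluoro does not register in the way the one on the other ring does.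

Nothing available here explains why the numbers move as they do. Still open, on these data alone, is how a hydroxy group, an amine or a longer chain such as ethoxy would behave at this ring position, and whether 2-methoxyphenyl would follow 2-fluorophenyl toward a low number.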